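The source may report more compounds than this note shows. Statements on the series, on what has been measured and on what is new or still open speak of the compounds shown alone.

Compound 1 `CCN(CC)C(=O)CC1CCc2cc(OC)c(OC)cc21`: 37.5%
Compound 2 `COc1cc2c(cc1OC)C(CC(=O)NC(C)(C)C)CC2`: 32.8%
Compound 3 `CCCCCNC(=O)CC1CCc2cc(OC)c(OC)cc21`: 40.6%

In a functional assay on the whole organism (strain Wistar) for inhibition, with Rattus norvegicus as the target, read by paw edema, with stated times of 60 min and 4 h, at a dose of 100 mg/kg by the oral route (on this read-out lower numbers stand for less inhibition and higher numbers for more inhibition at the one dose given (going by the name of the read-out)), compound 3 holds the top number of the three, but only by margins that stay within the scatter, as the steps of a number 3.1 percentage points higher from compound 1 to compound 3 (within the scatter) and a number 7.8 percentage points higher from compound 2 to compound 3 (within the scatter) show. Compound 4 `COc1cc2c(cc1OC)C(CC(=O)N1CCNCC1)CC2` differs from compound 3 in one place: piperazin-1-yl in place of pentylamino on a carbonyl carbon. All three measured steps also exchange the group on the carbonyl carbon, and none of them moved the read-out beyond the scatter: a number 4.7 percentage points lower from compound 1 to compound 2 (within the scatter), a number 3.1 percentage points higher from compound 1 to compound 3 (within the scatter), a number 7.8 percentage points higher from compound 2 to compound 3 (within the scatter). On that basis the author expects no step beyond the scatter for compound 4, an expected change of a number 4.6 percentage points lower from compound 3 to compound 4 (within the scatter). The estimate for compound 4 is 36%, in a range from 24% to 48%.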

Compound 4, a percentage reported as inhibition, in the whole organism at one dose (the size of the read-out at that dose, not a potency): 40.6%
Beside the measured number, compound 4's estimate is 4.6 percentage points below it; the measured number falls inside the stated range.
By their numbers in this assay, from the lowest: compounds 2, 1, 3 and 4 (each within the scatter of the next).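

In this assay, going by these compounds alone, piperazin-1-yl is the first ring on the carbonyl carbon, and it stays within the scatter of pentylamino (no change at the digits printed from compound 3 to compound 4 (within the scatter)), (tert-butyl)amino (a number 7.8 percentage points higher from compound 2 to compound 4 (within the scatter)) and diethylamino (a number 3.1 percentage points higher from compound 1 to compound 4 (within the scatter)). At this place, then, a six-membered non-aromatic ring with 2 hetero atoms reads like the open-chain groups. Nothing available here bears on why the read-out holds level. Left open is whether morpholin-4-yl, anilino or a carboxylic acid on the carbonyl side chain would give a step beyond the scatter.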